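Two Amides Measured, a Pyridinyl Variant Still Untested

The compounds below may be only part of what the source reports. "The series", "measured", "known", "first", "only" and "open" are said of these compounds alone.

Compound 1 `COc1ccc2nc(C)cc(OCC(=O)Nc3ccccc3)c2c1`: 39800 nM
Compound 2 `COc1ccc2nc(C)cc(OCC(=O)Nc3ccc(Cl)cc3Cl)c2c1`: > 100000 nM

In a toxicity assay on HepG2 cells (Homo sapiens) for inhibition, read by CellTiter-Glo, with a stated time of 48 h (on this read-out higher numbers stand for weaker inhibition and lower numbers for stronger inhibition), compound 1 gives 39800 nM. Compound 2 reaches only > 100000 nM, which is a limit of the measurement rather than a number, so compound 2 stands as a limit alone. For the measured compounds named here, the step of an at least 2.5-fold higher number from compound 1 to compound 2 (0.40 log units; beyond the scatter) is the only measured change here. Compound 3 `COc1ccc2nc(C)cc(OCC(=O)Nc3ccccn3)c2c1` differs from compound 2 by pyridin-2-yl in place of 2,4-dichlorophenyl on an amide-type nitrogen. Going by the values given here, no measured step covers this change; both measured compounds inhibit weakly, and the limit of > 100000 nM in this assay, at which 1 of the 2 values shown sits, caps what is seen. Compound 3 is therefore expected to remain weak, with an estimated step of an at least 1.4-fold lower number from compound 2 to compound 3 (0.15 log units; that floor lies within the scatter). The estimate for compound 3 is 70000 nM, expected between 25000 nM and 100000 nM.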

Compound 3, half-maximal inhibitory concentration: > 100000 nM
Compound 3: a limit, no number (the forecaster's own chance of this, stated with the estimate: 50%); middle value at least 1.4-fold (0.15 log units) away from the limit.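

In this assay, pyridin-2-yl in place of phenyl on the amide-type nitrogen gives an at least 2.5-fold higher number from compound 1 to compound 3 (0.40 log units; beyond the scatter), so a second replacement at this position also moves the number the same way as 2,4-dichlorophenyl did. Compound 2 and compound 3 are both limits rather than numbers, so the step between them cannot be read. Most of the values now sit at one ceiling: the limit of > 100000 nM in this assay, at which 2 of the 3 values shown sit.

As far as these compounds go, whether any group on this nitrogen gives stronger inhibition than compound 1 stays open. A phenyl ring carrying an amine or a carboxylic acid, or a longer chain in place of the ring, could test that.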